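The compounds below may be only part of what the source reports. "The series", "measured", "known", "first", "only" and "open" are said of these compounds alone.

Compound 1 `C#CCSc1nc(Nc2ccccc2)c2ccncc2n1` carries an unsubstituted phenyl on the amine nitrogen of the shared core. In a functional assay on HepG2 cells (Homo sapiens) for inhibition, read by MTT assay, with a stated time of 72 h (on this read-out higher numbers stand for weaker inhibition and lower numbers for stronger inhibition), compound 1 gives 29400 nM, the highest number of the three measured compounds. Compound 2 `C#CCSc1nc(Nc2ccc(F)cc2)c2ccncc2n1` gives 10800 nM in this assay, and compound 3 `C#CCSc1nc(Nc2cccc(Cl)c2)c2ccncc2n1` gives 1090 nM. Measured as steps, there is a 2.7-fold lower number from compound 1 to compound 2 (0.43 log units; beyond the scatter), there is a 27-fold lower number from compound 1 to compound 3 (1.43 log units; beyond the scatter), and between the two substituted compounds there is a 9.9-fold lower number from compound 2 to compound 3 (1.00 log units; beyond the scatter).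

Compound 4 `C#CCSc1nc(Nc2ccc([N+](=O)[O-])cc2)c2ccncc2n1` has not yet been measured in this assay. It differs from compound 1 in one place: nitro in place of hydrogen on an aromatic carbon. Among the compounds with values here, two measured steps bear on this change, both of them a single substituent entering the phenyl ring of compound 1: the modest lowering seen from compound 1 to compound 2 and the large lowering seen from compound 1 to compound 3. Compound 4 places its nitro where compound 2 places its fluoro, so the modest step is taken as the closer guide, with some allowance for the larger one. The expected step is therefore a lowering of the number, estimated as a 4.2-fold lower number from compound 1 to compound 4 (0.62 log units; beyond the scatter). Compound 4 is thus expected to give about 7000 nM in this assay, with a range from 2000 nM to 25000 nM.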

Compound 4, half-maximal inhibitory concentration: > 80000 nM
Compound 4 gave a limit, no number (the forecaster's own chance of this, stated with the estimate: 5%); middle value at least 11-fold (1.05 log units) from the limit.
By their numbers in this assay, from the lowest: compound 3; then compound 2; then compound 1. At a limit, above all of these: compound 4.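

Compound 4 is recorded in this assay only as a limit, not as a number: the limit of > 80000 nM in this assay, at which 1 of the 4 values shown sits. Until now, both single substituents entering the phenyl ring of compound 1 had lowered the number, but nitro on the aromatic carbon para to a large group reverses that direction, with an at least 2.7-fold higher number from compound 1 to compound 4 (0.43 log units; beyond the scatter). As far as these compounds go, at this same place, the outcome therefore depends on the group that enters, as the exchange of fluoro for nitro gives an at least 7.4-fold higher number from compound 2 to compound 4 (0.86 log units; beyond the scatter), and because compound 4 stands at a limit, the true size of both steps remains unknown.

The compounds shown do not tell whether other groups at this place, such as an amine, a methoxy group or a carboxylic acid, would follow fluoro or nitro, so the reversal rests on nitro alone. They also leave open whether nitro on the carbon that carries chloro in compound 3 would raise the number in the same way, and they offer no measurement that explains why nitro behaves differently from fluoro.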